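This account rests on a few compounds, and the source may have more. Where it says the series, first, only, none or still open, it means among the compounds named here.

Compound 1 `COC(=O)c1cccc(NC(=O)C2CCCN(C(=O)c3cc(C(F)(F)F)cc(C(F)(F)F)c3)C2)c1` carries a methoxycarbonyl group on the anilide ring of the shared core. In an ADME assay on PC-3 cells (Homo sapiens) for cytotoxicity, read by WST assay, tested at 100 uM (on this read-out higher numbers stand for more inhibition at the one concentration tested (going by the name of the read-out) and lower numbers for less inhibition), compound 1 gives 0%. That number is level with the result of compound 2 `N#Cc1cccc(C(=O)N2CCCC(C(=O)Nc3ccc(Cl)cc3)C2)c1`, which in this assay gives 0%, and together these two stand lowest of the three numbers seen so far; compound 3 `O=C(Nc1ccc(Cl)cc1)C1CCCN(C(=O)c2cccc(-c3cccs3)c2)C1` gives 4%, a result that lies within the scatter of the other two.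

Compound 4 `Cn1cnnc1-c1cccc(NC(=O)C2CCCN(C(=O)c3cc(C(F)(F)F)cc(C(F)(F)F)c3)C2)c1` differs from compound 1 in one place: 4-methyl-4H-1,2,4-triazol-3-yl in place of methoxycarbonyl on an aromatic carbon.

Among the measured compounds shown here, only one measured step exists, a number 4 percentage points higher from compound 2 to compound 3 (within the scatter), and it changes a group on the other side of the core, the benzoyl ring, not the anilide ring altered here. It nevertheless shows that a sizeable change of an aromatic substituent left this assay flat. For the measured compounds named here, no measured step covers the anilide ring itself. With all three compounds at the floor of the read-out, compound 4 is expected to stay there too, a step of a number 2 percentage points higher from compound 1 to compound 4 (within the scatter), meaning no change beyond the scatter. The estimated value for compound 4 is therefore 2%, within a range from -8% to 14%.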

Compound 4, a percentage reported as inhibition, at one concentration (the size of the read-out at that concentration, not a potency): 0%
For compound 4 the middle estimate is 2 percentage points above the measured one; the range from low to high includes it.
By their numbers in this assay, from the lowest: compounds 1, 2, 4 and 3 (each within the scatter of the next).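

Swapping methoxycarbonyl for 4-methyl-4H-1,2,4-triazol-3-yl gives, in this assay, no change at the digits printed from compound 1 to compound 4 (within the scatter), and this is the first step shown at this place on the shared core. A group with no ring and a five-membered aromatic ring with 3 hetero atoms therefore read the same here, while the earlier step covered a different place on the core. No measurement offered here bears on why the read-out stayed the same.

Since compound 1 and compound 4 both sit at the bottom of the read-out, this step cannot show whether any group at this place could raise the number. An amine or a carboxylic acid on this same aromatic carbon remains an open case.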